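A few compounds are considered here, and "the series" means these few. Any claim that something is new, unique, unknown or untested is made for them only; others in the source may bear on it.

Measured in a functional assay on MCF7 cells (Homo sapiens) for cytotoxicity, read by sulforhodamine B assay, with a stated time of 48 h; on this read-out higher numbers stand for weaker inhibition and lower numbers for stronger inhibition:
- compound 1 `O=C(c1cccnc1)c1cc(F)ccc1O` gives 27800 nM
- compound 2 `O=C(c1cccnc1)c1ccccc1O` gives 24600 nM
- compound 3 `C=CCOc1c(Cl)cccc1C(=O)c1cccnc1` gives > 100000 nM, a limit of the assay and not a number

Among the measured compounds shown here, compound 2 holds one of only two true numbers and stands within the scatter of compound 1. The step under study leads to compound 4 `O=C(c1cccnc1)c1cc(Cl)ccc1O`, with chloro in place of hydrogen on an aromatic carbon; in words, chloro in place of hydrogen on an aromatic carbon, para to a hydroxy group. For the measured compounds named here, one measured step bears on this carbon, the exchange of fluoro and hydrogen: a 1.1-fold lower number from compound 1 to compound 2 (0.05 log units; within the scatter). On that single step, no change beyond the scatter is expected in this assay. The expected step is a 1.1-fold lower number from compound 2 to compound 4 (0.05 log units; within the scatter). For compound 4 the estimate is 22000 nM, with an expected range of 10000 nM to 50000 nM.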

Compound 4, half-maximal inhibitory concentration: 29000 nM
For compound 4 the middle estimate is 1.3-fold (0.12 log units) below the measured one; the measured number falls inside the stated range.
By their numbers in this assay, from the lowest: compounds 2, 1 and 4 (each within the scatter of the next). At a limit, above all of these: compound 3.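

In this assay this aromatic carbon, para to a hydroxy group, now takes a second halogen: a 1.2-fold higher number from compound 2 to compound 4 (0.07 log units; within the scatter) and a 1.0-fold higher number from compound 1 to compound 4 (0.02 log units; within the scatter) leave hydrogen, fluoro and chloro here not told apart. Earlier only fluoro and hydrogen had been compared at this carbon, so the flat reading now spans two halogens. On these data alone, whether an amine, a carboxylic acid or a longer chain on this carbon would also stay within the scatter of compound 2 remains open. Nothing at hand speaks to a cause of this flat reading.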